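Aryloxypropyl ethers on a shared core: antiproliferative notes

This account rests on a few compounds, and the source may have more. Where it says the series, first, only, none or still open, it means among the compounds named here.

The series keeps one core and varies the aryl group on the ether oxygen. Compound 1 `COc1ccc(OCCCON2C(N)=NC(N)=NC23CCOCC3)cc1` gives "not determined" (no result reported) in a functional assay on MDA-MB-231 cells (Homo sapiens) for antiproliferative activity, read by MTT assay, with a stated time of 72 h (a lower number here means a stronger inhibitor, a higher number a weaker inhibitor), and compound 3 `NC1=NC2(CCOCC2)N(OCCCOc2ccc(Cl)cc2Cl)C(N)=N1` gives "not determined" (no result reported) in this assay; compound 3 therefore stands without a value in this assay, as does compound 1. Compound 2 `Cc1cc(C)cc(OCCCON2C(N)=NC(N)=NC23CCOCC3)c1` gives 3570 nM in this assay and is the only measured point. Compound 4 `NC1=NC2(CCOCC2)N(OCCCOc2cccc(Br)c2)C(N)=N1` differs from compound 3 by 3-bromophenyl in place of 2,4-dichlorophenyl on an oxygen on a saturated carbon. Among the measured compounds shown here, no measured step between these compounds exists, so the size and direction of the change from compound 3 to compound 4 in this assay cannot be read from the series; nothing beyond the usual scatter is expected. Compound 4 is estimated to give about 4000 nM in this assay, with a likely range of 1500 nM to 12000 nM.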

Compound 4, half-maximal inhibitory concentration: 400 nM
Beside the measured number, compound 4's estimate is 10-fold (1.00 log units) above it; measured number below the stated range.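

The aryl group on the ether oxygen matters in this assay: the series now has a readable step, an 8.9-fold lower number from compound 2 to compound 4 (0.95 log units; beyond the scatter), with 3-bromophenyl in place of 3,5-dimethylphenyl. The earlier compounds shown here gave one number and no step, so this position could not be judged before; the change now lies beyond the scatter, for this single pair. Nothing shown accounts for the step.

Steps involving compound 1 or compound 3 cannot be read. Open, from the compounds shown here alone, is how 3-chlorophenyl, an aryl group carrying an amine, or a longer chain would read at this position.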